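A few compounds are considered here, and "the series" means these few. Any claim that something is new, unique, unknown or untested is made for them only; others in the source may bear on it.

Compound 1, with the structure `Cc1ccc(/C=C2\CN(C(=S)SCc3cn(Cc4ccccc4F)nn3)C/C(=C\c3ccc(C)cc3)C2=O)cc1`, belongs to a small set of related compounds tested for their ability to kill a mouse tumour cell line. In a functional assay on 4T1 cells (Mus musculus) for cytotoxicity, read by MTT assay, with a stated time of 24 h (on this read-out lower numbers stand for stronger inhibition and higher numbers for weaker inhibition), compound 1 gives 28400 nM.

Two close relatives share a different core. Compound 3, with the structure `COc1ccc(/C=C2\CN(Cc3cn(Cc4ccccc4F)nn3)C/C(=C\c3ccc(OC)cc3)C2=O)cc1`, gives 39400 nM in this assay. Compound 2, with the structure `COc1ccc(/C=C2\CN(Cc3cn(Cc4ccccc4Cl)nn3)C/C(=C\c3ccc(OC)cc3)C2=O)cc1`, gives 11400 nM. The difference between these two is a single change, (chloro in place of fluoro on an aromatic carbon), and it produced a 3.5-fold lower number from compound 3 to compound 2 (0.54 log units; beyond the scatter). How the core of compound 1 differs from the core of compound 3 is not broken down here; the two cores simply differ in more than one place.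

Compound 4, with the structure `Cc1ccc(/C=C2\CN(C(=S)SCc3cn(Cc4ccccc4Cl)nn3)C/C(=C\c3ccc(C)cc3)C2=O)cc1`, has not yet been measured. Going by the values given here, it differs from compound 1 by chloro in place of fluoro on an aromatic carbon, which is the same change as the one from compound 3 to compound 2, at the same kind of place on the ring. The expectation that compound 4 will be more potent than compound 1 rests on that single earlier example, and the step is estimated at a 2.6-fold lower number from compound 1 to compound 4 (0.41 log units; beyond the scatter), somewhat smaller than the measured one because a 3.5-fold lower number from compound 3 to compound 2 (0.54 log units; beyond the scatter) was seen on a different core and only once. On that basis compound 4 is expected to give about 11000 nM in this assay, with a likely range from 4000 nM to 30000 nM.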

Compound 4, half-maximal inhibitory concentration: 49300 nM
Compound 4: middle estimate off by 4.5-fold (0.65 log units), on the low side; measured number outside the range, above it.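

On the core of compound 1, putting chloro in place of fluoro on the aromatic ring gives a 1.7-fold higher number from compound 1 to compound 4 (0.24 log units; within the scatter), so in this assay the two compounds cannot be told apart. The same swap therefore does not behave alike on the two cores, and the clear drop in the number seen on one core cannot be assumed to carry over to the other: the same change on two cores in this assay, a 3.5-fold lower number (0.54 log units; beyond the scatter) from compound 3 to compound 2 and a 1.7-fold higher number (0.24 log units; within the scatter) from compound 1 to compound 4, 6.0-fold (0.78 log units) apart, beyond the scatter of two such steps. Going by these compounds alone, this does not show why the two cores respond differently, since they differ in more than one place and each offers only a single pair, nor does it give a rule for how this swap will behave on any further core.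

The compounds shown leave open which of the differences between the two cores decides the outcome, a question that needs pairs of compounds differing at only one of those places. They also leave open how a bromo or a nitrile group in the same place on the ring would compare with fluoro and chloro on each core, and whether such groups would also respond differently from one core to the other.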